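The source may hold more compounds than are shown below. What is called first, only, known or untested is meant among the compounds shown, and "the series" means these compounds.

Compound 1 `Clc1cccc(/N=N/N2CCCCC2)c1`: > 100000 nM (a limit)
Compound 2 `O=[N+]([O-])c1ccc(/N=N/N2CCCC2)cc1`: 90000 nM

Both compounds were tested in an ADME assay on Vero cells (Chlorocebus sabaeus) for cytotoxicity, read by crystal violet staining; on this read-out lower numbers stand for higher toxicity in this test and higher numbers for lower toxicity in this test. Compound 1 gives only a limit of the assay, not a number, at > 100000 nM. Compound 3 `Brc1cccc(/N=N/N2CCCCC2)c1` differs from compound 1 in one place: bromo in place of chloro on an aromatic carbon. This puts bromo in place of chloro on an aromatic carbon. Within the data shown here, no measured pair shows this swap, so no direction can be read from the data. In this assay, the expected change is a number no higher from compound 1 to compound 3 (the limit leaves the size open), no larger than the usual scatter. Compound 3 is estimated at 100000 nM, within an expected range of 50000 nM to 200000 nM.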

Compound 3, half-maximal cytotoxic concentration: 85000 nM
Estimate against measurement, compound 3: 1.2-fold (0.07 log units) above; the measured number falls inside the stated range.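

With bromo in place of chloro at this position, the change gives a step that can be read only in part: an at least 1.1-fold lower number from compound 1 to compound 3 (0.07 log units; that floor lies within the scatter). Compound 1 stands at a limit of this assay, > 100000 nM. The true size of the step stays open because that limit hides the real number for compound 1: the limit of > 100000 nM in this assay, at which 1 of the 3 values shown sits.

The compounds shown leave open how fluoro, methoxy or an amine on the same aromatic carbon would read. They also leave open whether this swap would give a similar step on another core.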